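The source may report more compounds than this note shows. Statements on the series, on what has been measured and on what is new or still open speak of the compounds shown alone.

Measured compounds:
- compound 1 `COc1ccc(/C=C/C(=O)Nc2cc(C(=O)c3cc(OC)c(OC)c(OC)c3)ccc2OC)cc1`: in a functional assay on HeLa cells (Homo sapiens) for cytotoxicity, read by MTT assay, with a stated time of 72 h (a higher number here means a weaker inhibitor, a lower number a stronger inhibitor), compound 1 gives 10700 nM
- compound 2 `COc1cc(/C=C/C(=O)Nc2cc(C(=O)c3cc(OC)c(OC)c(OC)c3)ccc2OC)ccc1F`: compound 2 gives 13600 nM
- compound 3 `COc1ccc(C(=O)c2cc(OC)c(OC)c(OC)c2)cc1NC(=O)/C=C/c1cccc(OC(F)(F)F)c1`: compound 3 gives 7900 nM

All three share one core and differ only in the ring on the double-bonded chain carbon bound to a double-bonded chain carbon. Compound 3 gives the smallest of the three numbers, but neither gap is more than scatter: a 1.4-fold lower number from compound 1 to compound 3 (0.13 log units; within the scatter) and a 1.7-fold lower number from compound 2 to compound 3 (0.24 log units; within the scatter). The third step, a 1.3-fold higher number from compound 1 to compound 2 (0.10 log units; within the scatter), is likewise within the scatter. Across these three rings, then, no change at that position has moved the number beyond repeat-measurement noise.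

Compound 4 `COc1ccc(C(=O)c2cc(OC)c(OC)c(OC)c2)cc1NC(=O)/C=C/c1ccc(F)c(F)c1` is the next variation at the same place: 3,4-difluorophenyl in place of 3-(trifluoromethoxy)phenyl on a double-bonded chain carbon bound to a double-bonded chain carbon. All three measured steps bear on it, since each swaps the ring at this position, and each was within the scatter. The expectation for compound 4 is therefore a step of about a 1.1-fold higher number from compound 3 to compound 4 (0.06 log units; within the scatter) from compound 3 in this assay, that is, no movement beyond the scatter in either direction. Compound 4 is estimated at 9000 nM, with a range from 4500 nM to 18000 nM.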

Compound 4, half-maximal inhibitory concentration: 8100 nM
The estimate for compound 4 lay 1.1-fold (0.05 log units) above the measured number, and the stated range covers the measured number.
By their numbers in this assay, from the lowest: compounds 3, 4, 1 and 2 (each within the scatter of the next).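

The ring at this position can lose its oxygen without a reading change: going from 3-(trifluoromethoxy)phenyl, with 11 heavy atoms and 1 hydrogen-bond acceptor, to 3,4-difluorophenyl, with 8 heavy atoms and 0 hydrogen-bond acceptors, gives a 1.0-fold higher number from compound 3 to compound 4 (0.01 log units; within the scatter) in this assay. The swap of methoxy for fluoro on an aromatic carbon points the same way, with a 1.7-fold lower number from compound 2 to compound 4 (0.23 log units; within the scatter), and the full ring change gives a 1.3-fold lower number from compound 1 to compound 4 (0.12 log units; within the scatter), so compound 4, the only one here with fluoro alone on this ring, stands within the scatter of all three others. No measurement shown here speaks to the cause of this flat reading.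

Open, as far as these compounds go, is whether an amine or a carboxylic acid on this ring, or a longer chain in place of the ring, would move the number beyond the scatter in this assay. Also open, from the compounds shown here alone, is whether any change to the shared core, such as replacing the amide hydrogen with a methyl group, would shift the readings that these four rings leave unmoved.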